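The source may hold more compounds than are shown below. What is called first, only, known or untested is meant among the compounds shown, and "the series" means these compounds.

Three cinnamamides of a shared benzothiazole-type core have been measured in a functional assay on the whole organism (Hindlimb, strain albino) with Mus musculus as the target, in the maximal electroshock model, with a stated time of 0.5 h; a lower number here means that less compound is needed, a higher number that more compound is needed for the effect. Compound 1, `Cc1ccc2nc(NC(=O)/C=C/c3ccc(O)cc3)sc2c1`, gives 271 umol/kg. Compound 2, `Cc1ccc2nc(NC(=O)/C=C/c3ccccc3)sc2c1`, gives 380 umol/kg. Compound 3, `COc1ccc(/C=C/C(=O)Nc2nc3ccccc3s2)cc1O`, gives 495 umol/kg. The step of a 1.4-fold higher number from compound 1 to compound 2 (0.15 log units; within the scatter) is the change (hydrogen in place of hydroxy on an aromatic carbon); its two values lie within the usual scatter of each other, so nothing can be said about its direction. Compound 3 stands within the scatter of both compound 1 and compound 2. The difference between the core of compound 3 and the core of compound 1 is not broken down here.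

Compound 4, `COc1ccc(/C=C/C(=O)Nc2nc3ccccc3s2)cc1`, is not yet measured. It differs from compound 3 by hydrogen in place of hydroxy on an aromatic carbon. This is the same kind of change as that from compound 1 to compound 2, but the place is not the same: in compound 1 the hydroxy sits para to a large group, while in compound 3 it sits ortho to a methoxy group (2 heavy atoms) and meta to a large group.

For compound 4 the expected step is a 1.2-fold higher number from compound 3 to compound 4 (0.08 log units; within the scatter), resting on the size of the earlier step of a 1.4-fold higher number from compound 1 to compound 2 (0.15 log units; within the scatter), which stayed within the scatter. Since that one precedent is small and comes from a differently placed hydroxy, the expectation for compound 4 is loose: in this assay compound 4 is estimated at 600 umol/kg, with a likely span from 300 umol/kg to 1200 umol/kg.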

Compound 4, dose for half-maximal effect: 435 umol/kg
Estimate against measurement, compound 4: 1.4-fold (0.14 log units) above; the range from low to high includes it.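

In this assay, putting hydrogen in place of the hydroxy that sits ortho to a methoxy group and meta to a large group gives a 1.1-fold lower number from compound 3 to compound 4 (0.06 log units; within the scatter), so no direction can be read from this step. Set beside the earlier case of the same change, the new step does not differ from it: the same change on two cores in this assay, a 1.4-fold higher number (0.15 log units; within the scatter) from compound 1 to compound 2 and a 1.1-fold lower number (0.06 log units; within the scatter) from compound 3 to compound 4, 1.6-fold (0.20 log units) apart, within the scatter of two such steps. Among these compounds, this shows only that the exchange stayed within the scatter on both cores; it does not show that the change carries over with a fixed size or direction, or that the hydroxy is without any influence, as these are just two small steps, the hydroxy stands in a different place in each pair, and the cores differ as well.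

The compounds shown leave open whether a step beyond the scatter would appear with an amine or a carboxylic acid in place of the hydroxy, or with a longer chain such as an ethoxy or propoxy group in place of the methoxy group. They also leave open how much the core alone contributes, as no two of these compounds differ only there.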